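Removing the Methylbenzyl Group: An Unsubstituted Anilide Is Next

The source may hold more compounds than are shown below. What is called first, only, known or untested is meant among the compounds shown, and "the series" means these compounds.

Compound 1 `O=C(/C=C/c1coc2cc(O)ccc2c1=O)NCc1ccccc1` gives 4690 nM in a functional assay on Huh-7 cells (Homo sapiens) for inhibition, read by MTT assay, with a stated time of 48 h; a higher number here means a weaker inhibitor, a lower number a stronger inhibitor; compound 2 `Cc1ccccc1NC(=O)/C=C/c1coc2cc(O)ccc2c1=O` gives 11100 nM in this assay; compound 3 `Cc1ccc(CNC(=O)/C=C/c2coc3cc(O)ccc3c2=O)cc1` shows only the limit > 100000 nM in this assay.

Compound 3 therefore stands at the weak end of the three: its number is a limit of the assay, not a measured value, as the line the limit of > 100000 nM in this assay, at which 1 of the 3 values shown sits, records. The step to compound 4 `O=C(/C=C/c1coc2cc(O)ccc2c1=O)Nc1ccccc1` is phenyl in place of 4-methylbenzyl on an amide-type nitrogen. Among the measured compounds shown here, two measured steps bear on it. The change from benzyl to 2-methylphenyl gave a 2.4-fold higher number from compound 1 to compound 2 (0.37 log units; beyond the scatter), a modest loss. The change from 2-methylphenyl to 4-methylbenzyl gave an at least 9.0-fold higher number from compound 2 to compound 3 (0.95 log units; beyond the scatter), a far larger loss, and from compound 1 the single added methyl gave an at least 21-fold higher number from compound 1 to compound 3 (1.32 log units; beyond the scatter). Compound 4 removes the 4-methylbenzyl that marks the weakest measured compound and carries a plain phenyl on the amide-type nitrogen, so a return towards the numbers of compound 1 and compound 2 is expected, a step downward and beyond the scatter. The estimate for compound 4 in this assay is 8000 nM, with a range from 2500 nM to 40000 nM, which means an expected step of an at least 12-fold lower number from compound 3 to compound 4 (1.09 log units; beyond the scatter).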

Compound 4, half-maximal inhibitory concentration: 3880 nM
Estimate against measurement, compound 4: 2.1-fold (0.31 log units) above, within the range that was stated.
By their numbers in this assay, from the lowest: compounds 4 and 1 (each within the scatter of the next); then compound 2. At a limit, above all of these: compound 3.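

In this assay, phenyl in place of 4-methylbenzyl on the amide-type nitrogen gives an at least 25-fold lower number from compound 3 to compound 4 (1.41 log units; beyond the scatter), so this nitrogen can carry an aromatic ring without the loss seen with compound 3. The number for compound 3 is a limit and not a measured value: the limit of > 100000 nM in this assay, at which 1 of the 4 values shown sits. Phenyl and benzyl are not separated, at a 1.2-fold lower number from compound 1 to compound 4 (0.08 log units; within the scatter), while losing the methyl from 2-methylphenyl gives a 2.9-fold lower number from compound 2 to compound 4 (0.46 log units; beyond the scatter), so the methyl raises the number in both pairs, though by clearly different amounts: the same change on two cores in this assay, an at least 21-fold higher number (1.32 log units; beyond the scatter) from compound 1 to compound 3 and a 2.9-fold higher number (0.46 log units; beyond the scatter) from compound 4 to compound 2, at least 7.4-fold (0.87 log units) apart, beyond the scatter of two such steps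

The compounds shown leave open how this position responds to anything other than a methyl on the aromatic ring, such as a chlorine, a methoxy group or a carboxylic acid there, or to a longer chain such as phenylethyl on the amide-type nitrogen. They also give no reason why the added methyl matters so much more with benzyl than with phenyl, and they do not show whether a methyl placed elsewhere on either ring would behave the same way.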